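Thiosemicarbazone series: aryl swap at the imine carbon

The source may report more compounds than this note shows. Statements on the series, on what has been measured and on what is new or still open speak of the compounds shown alone.

Measured so far:
compound 1 `CC1=CC[C@H](C(C)(C)NC(=S)N/N=C/c2ccccc2)CC1` — 71400 nM
compound 2 `CC1=CC[C@H](C(C)(C)NC(=S)N/N=C/c2ccc[nH]2)CC1` — 3900 nM

Among the measured compounds shown here, in a functional assay on U-251 cells (Homo sapiens) for inhibition, read by sulforhodamine B assay, with a stated time of 48 h (on this read-out higher numbers stand for weaker inhibition of growth and lower numbers for stronger inhibition of growth), compound 2 holds the lowest number of the two, with compound 1 as its only neighbour at an 18-fold lower number from compound 1 to compound 2 (1.26 log units; beyond the scatter). Compound 3 `CC1=CC[C@H](C(C)(C)NC(=S)N/N=C/c2cccs2)CC1` is not yet measured; it differs from compound 2 by thiophen-2-yl in place of 1H-pyrrol-2-yl on a carbon with a double bond to nitrogen. For the measured compounds named here, no measured step covers a thiophen-2-yl ring, so only the step from compound 1 to compound 2 bears on it, and only indirectly: that step, an 18-fold lower number from compound 1 to compound 2 (1.26 log units; beyond the scatter), went with the entry of a ring counted with one hydrogen-bond donor, whereas the ring entering in compound 3 is counted with none, as in compound 1. Compound 3 is therefore expected to give back part of that gain, a step of a 3.8-fold higher number from compound 2 to compound 3 (0.59 log units; beyond the scatter) in this assay, a higher number than compound 2 but not as high as compound 1. The estimate for compound 3 in this assay is 15000 nM, with a range of 4000 nM to 60000 nM.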

Compound 3, concentration for total growth inhibition: 27400 nM
Compound 3: middle estimate off by 1.8-fold (0.26 log units), on the low side, and the stated range covers the measured number.
By their numbers in this assay, from the lowest: compound 2; then compound 3; then compound 1.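

In this assay, the ring on the carbon with a double bond to nitrogen matters beyond its size and its aromatic five-membered form: 1H-pyrrol-2-yl and thiophen-2-yl match in both and in heavy-atom count, yet the swap gives a 7.0-fold higher number from compound 2 to compound 3 (0.85 log units; beyond the scatter). A five-membered ring without a counted hydrogen-bond donor still differs from phenyl, with a 2.6-fold lower number from compound 1 to compound 3 (0.42 log units; beyond the scatter), so the donor count alone does not separate the three compounds: compound 1 and compound 3 share it but do not share a level of growth inhibition. No measured data bear on the reason for either step.

Open, going by these compounds, is how 1-methyl-1H-pyrrol-2-yl, which keeps the ring of compound 2 but carries methyl in place of the ring hydrogen on nitrogen, would fall in this order. On these data alone, the places of furan-2-yl, with oxygen as its hetero atom, and pyridin-2-yl, a six-membered ring with nitrogen, are equally open.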